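This account rests on a few compounds, and the source may have more. Where it says the series, first, only, none or still open, it means among the compounds named here.

Values in a functional assay on cells (T-cell line, Homo sapiens) for inhibition; on this read-out higher numbers stand for weaker inhibition and lower numbers for stronger inhibition:
- compound 1 `COc1ccc(CCCN2CCC(C(O)CC(c3ccccc3)c3ccccc3)CC2)cc1` gives 1500 nM
- compound 2 `COc1ccc(CCCN2CCC(CCC(c3ccccc3)c3ccccc3)CC2)cc1` gives 200 nM
- compound 3 `Clc1ccc(CCCN2CCC(COC(c3ccccc3)c3ccccc3)CC2)cc1Cl` gives 2200 nM

Compound 3 at 2200 nM lies within the scatter of compound 1, and compound 2 at 200 nM gives the lowest number of the set, well under both.

The next compound is compound 4 `CCCCCCCCN1CCC(COC(c2ccccc2)c2ccccc2)CC1`, with pentyl in place of 3,4-dichlorophenyl on a saturated chain carbon, three bonds along the chain from an amine nitrogen in a ring.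

Going by the values given here, no measured step changes this group. Among the compounds with values here, the only step available, a 7.5-fold lower number from compound 1 to compound 2 (0.88 log units; beyond the scatter), is hydrogen in place of hydroxy at another place on the molecule, and it shows only that this series can move beyond the scatter with a single change. It gives neither a size nor a direction for the present change, so no shift beyond the scatter is expected, with wide uncertainty.

The expected step is a 1.2-fold lower number from compound 3 to compound 4 (0.09 log units; within the scatter).

For compound 4 the estimated value in this assay is 1800 nM, with an expected range from 500 nM to 6000 nM.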

Compound 4, half-maximal inhibitory concentration: 700 nM
For compound 4 the middle estimate is 2.6-fold (0.41 log units) above the measured one; the range from low to high includes it.
By their numbers in this assay, from the lowest: compound 2; then compound 4; then compounds 1 and 3 (each within the scatter of the next).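

In this assay, replacing 3,4-dichlorophenyl with pentyl on a saturated chain carbon, three bonds along the chain from an amine nitrogen in a ring, gives a 3.1-fold lower number from compound 3 to compound 4 (0.50 log units; beyond the scatter). Going by these compounds alone, this is the first measured change at this position, and it shows that an aromatic ring is not required there for inhibition: pentyl, with no ring, gives the lower number. No measurement available accounts for this step.

A single pair changes the ring, both chlorines and the group's size at once, so it cannot show which of these differences matters. Unsubstituted phenyl at this place would separate the chlorines from the ring, while a shorter chain such as propyl and a longer one such as octyl would show how the number follows chain length.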